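Cyclopentyl in place of cyclopropyl: what to expect

The compounds below may be only part of what the source reports. "The series", "measured", "known", "first", "only" and "open" are said of these compounds alone.

Compound 1 `Cc1nc[nH]c1CN[C@@H]1C[C@@H]2C[C@H]([C@H]1C)C2(C)C` gives 252000 nM
Compound 2 `C[C@@H]1[C@H]2C[C@@H](C[C@H]1NCc1cnc(C3CC3)[nH]1)C2(C)C` gives 94500 nM

In an ADME assay on MDCK cells (Canis lupus familiaris) for cytotoxicity, read by MTT assay, with a stated time of 48 h (a higher number here means that more compound is tolerated, a lower number that less compound is tolerated), compound 2 (94500 nM) holds the lower number of the two, and the gap to compound 1 (252000 nM) lies beyond the usual scatter. Compound 3 `C[C@@H]1[C@H]2C[C@@H](C[C@H]1NCc1cnc(C3CCCC3)[nH]1)C2(C)C` carries cyclopentyl in place of cyclopropyl on an aromatic carbon. Among the measured compounds shown here, no measured pair of compounds isolates a change like this one, so any forecast is loose. The expected move is a 2.1-fold lower number from compound 2 to compound 3 (0.32 log units; beyond the scatter) towards less compound tolerated, a modest step that may not clear the scatter. Compound 3 is estimated at 45000 nM (15000 nM to 110000 nM).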

Compound 3, half-maximal cytotoxic concentration: 37200 nM
For compound 3 the middle estimate is 1.2-fold (0.08 log units) above the measured one; low and high end bracket the measured number.
By their numbers in this assay, from the lowest: compound 3; then compound 2; then compound 1.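

Among the compounds shown here, compound 2 and compound 3 form the only measured pair that isolates a single change, so this position can now be read directly. In this assay, cyclopentyl in place of cyclopropyl on an aromatic carbon gives a 2.5-fold lower number from compound 2 to compound 3 (0.40 log units; beyond the scatter), so the ring carried at this carbon, between two ring nitrogen atoms, does affect how much compound is tolerated. No available evidence explains this step. The compounds shown leave open whether cyclobutyl would fall between these two rings. They also leave open how an open chain such as isopropyl, or an amine, would behave here.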